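Swapping dimethylamino for methoxy: a small step expected

This account rests on a few compounds, and the source may have more. Where it says the series, first, only, none or still open, it means among the compounds named here.

- Compound 1 `COc1ccc(S(=O)(=O)N2CCc3cccc(-c4ccco4)c32)cc1`: 79.2 nM
- Compound 2 `COc1ccc(S(=O)(=O)N2CCc3cccc(-c4ccc(N(C)C)cc4)c32)cc1`: 553 nM

In a functional assay on KB-VIN10 cells (Homo sapiens) for inhibition, with a stated time of 72 h (on this read-out higher numbers stand for weaker inhibition and lower numbers for stronger inhibition), compound 2 has the higher of the two numbers, at 553 nM. Compound 3 `COc1ccc(-c2cccc3c2N(S(=O)(=O)c2ccc(OC)cc2)CC3)cc1` differs from it by methoxy in place of dimethylamino on an aromatic carbon. Among the compounds with values here, only one measured step bears on this change: a 7.0-fold higher number from compound 1 to compound 2 (0.84 log units; beyond the scatter), where 4-(dimethylamino)phenyl replaced furan-2-yl on an aromatic carbon. That was a larger exchange of groups, so a step beyond the scatter is not expected here, though a slightly lower number is. The expected step is a 1.6-fold lower number from compound 2 to compound 3 (0.20 log units; within the scatter). Compound 3 is estimated at 350 nM, with an expected range of 100 nM to 1100 nM.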

Compound 3, half-maximal inhibitory concentration: 352 nM
Compound 3: the middle estimate sits 1.0-fold (0.00 log units) below what was measured, within the range that was stated.
By their numbers in this assay, from the lowest: compound 1; then compounds 3 and 2 (each within the scatter of the next).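

In this assay, methoxy and dimethylamino on this aromatic carbon cannot be told apart, with a 1.6-fold lower number from compound 2 to compound 3 (0.20 log units; within the scatter). The 4-methoxyphenyl group also stands clearly apart from furan-2-yl, with a 4.4-fold higher number from compound 1 to compound 3 (0.65 log units; beyond the scatter), so among these compounds the gap to compound 1 goes with both 4-substituted phenyl groups, not with dimethylamino alone. No measurement shown accounts for either step. From the compounds shown here alone, it remains open whether an unsubstituted phenyl, or a phenyl carrying a carboxylic acid or a primary amine, would fall near compound 3 or near compound 1.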